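Propargyl to allyl amides: cytotoxicity expectation for compound 4

This account rests on a few compounds, and the source may have more. Where it says the series, first, only, none or still open, it means among the compounds named here.

Measured so far:
compound 1 `C=CCNC(=O)/C(C)=C(\C)c1cc(OC)c(OC)c(OC)c1`: 190 mg/kg
compound 2 `C#CCNC(=O)/C(C)=C(\C)c1cc(OC)c(OC)c(OC)c1`: 150 mg/kg
compound 3 `C#CCNC(=O)/C(C)=C(\C)c1ccc(C)cc1`: 150 mg/kg

In a toxicity assay on the whole organism (strain Icem-CET (SPF Caw)) for cytotoxicity, with Mus musculus as the target (on this read-out higher numbers stand for an effect only at larger amounts of compound and lower numbers for an effect already at smaller amounts), compound 1 gives 190 mg/kg and compound 2 gives 150 mg/kg. These two differ by vinyl in place of ethynyl on a saturated chain carbon bound to an amide-type nitrogen, a step of a 1.3-fold higher number from compound 2 to compound 1 (0.10 log units; within the scatter). Compound 3, on the other core, gives 150 mg/kg in this assay; the difference between the two cores is not broken down here, and the values of compound 3 and compound 2 show no change at the digits printed.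

Compound 4 `C=CCNC(=O)/C(C)=C(\C)c1ccc(C)cc1` is not yet measured. It differs from compound 3 by vinyl in place of ethynyl on a saturated chain carbon bound to an amide-type nitrogen, the same change as from compound 2 to compound 1. Because that step was a 1.3-fold higher number from compound 2 to compound 1 (0.10 log units; within the scatter), a step of similar size is expected here, a 1.3-fold higher number from compound 3 to compound 4 (0.10 log units; within the scatter). Compound 4 is therefore estimated to give 190 mg/kg in this assay, likely between 110 mg/kg and 330 mg/kg.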

Compound 4, dose for half-maximal effect: 150 mg/kg
Beside the measured number, compound 4's estimate is 1.3-fold (0.10 log units) above it, and the stated range covers the measured number.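

In this assay the change from propargyl to allyl on the core of compound 3 gives no change at the digits printed from compound 3 to compound 4 (within the scatter). Set beside the earlier step on the other core, the two results do not differ: the same change on two cores in this assay, a 1.3-fold higher number (0.10 log units; within the scatter) from compound 2 to compound 1 and no change at the digits printed (within the scatter) from compound 3 to compound 4, 1.3-fold (0.10 log units) apart, within the scatter of two such steps. On these two pairs the change carries from one core to the other with no step beyond the scatter, but this does not show that it is without effect on other cores, and a real effect smaller than the scatter cannot be told apart here.

Open, going by these compounds, is whether a longer chain in place of propargyl or allyl would stay level with these values. Also open, on these data alone, is whether an amine or a carboxylic acid at that place would do so.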